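From 3,4-dimethoxyphenyl to 4-(dimethylamino)phenyl: an expected step

The compounds below may be only part of what the source reports. "The series", "measured", "known", "first", "only" and "open" are said of these compounds alone.

In a functional assay on A549 cells (Homo sapiens) for cytotoxicity, read by MTT assay, with a stated time of 24 h (a higher number here means a weaker inhibitor, a lower number a stronger inhibitor), compound 1 (`COc1ccc(/C=C(\C#N)C(=O)N/N=C(\C)c2c(O)c3ccc(O)cc3oc2=O)cc1OC`) gives 14300 nM and compound 2 (`COc1cc(/C=C(\C#N)C(=O)N/N=C(\C)c2c(O)c3ccc(O)cc3oc2=O)cc(OC)c1OC`) gives 15300 nM as its number, so the two stand level within the scatter. Compound 3 (`C/C(=N\NC(=O)/C(C#N)=C/c1ccc(N(C)C)cc1)c1c(O)c2ccc(O)cc2oc1=O`) has not yet been measured. It differs from compound 1 by having 4-(dimethylamino)phenyl in place of 3,4-dimethoxyphenyl on a double-bonded chain carbon bound to a double-bonded chain carbon. For the measured compounds named here, the only measured step that bears on this is a 1.1-fold higher number from compound 1 to compound 2 (0.03 log units; within the scatter) and it merely puts methoxy in place of hydrogen on an aromatic carbon. Going by the values given here, no measured step replaces the whole group, so this small step is a weak guide and the range must stay wide. In this assay the expected step is a 1.0-fold lower number from compound 1 to compound 3 (0.01 log units; within the scatter) and so none beyond the scatter, in neither direction. For compound 3 the expected value is 14000 nM (estimated range 6000 nM to 30000 nM).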

Compound 3, half-maximal inhibitory concentration: 4310 nM
Estimate against measurement, compound 3: 3.2-fold (0.51 log units) above; the whole stated range lies above it.
By their numbers in this assay, from the lowest: compound 3; then compounds 1 and 2 (each within the scatter of the next).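

The extra methoxy of compound 2 left the number within the scatter, so the aromatic group on this double-bonded chain carbon could have seemed to matter little. Replacing the whole 3,4-dimethoxyphenyl with 4-(dimethylamino)phenyl shows otherwise: in this assay it gives a 3.3-fold lower number from compound 1 to compound 3 (0.52 log units; beyond the scatter), so the choice of group here can move the cytotoxicity number beyond the scatter. No measurement shown explains this shift.

From the compounds shown here alone, the change removes both methoxy groups and brings in dimethylamino in one step, so it remains open whether the lower number follows from losing the methoxy groups or from gaining the amine. A plain phenyl would help to separate these two readings, and 4-(diethylamino)phenyl would test whether larger groups on the amine nitrogen are tolerated.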